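Carbamoylmethyl for tert-butyl: expected cytotoxicity of compound 3

The compounds below may be only part of what the source reports. "The series", "measured", "known", "first", "only" and "open" are said of these compounds alone.

The series shares one core, varied only at a substituent on an aromatic nitrogen, and is read in an ADME assay on BaF3 cells (Mus musculus) for cytotoxicity; on this read-out higher numbers stand for an effect only at larger amounts of compound and lower numbers for an effect already at smaller amounts. Compound 1 `CCn1ncc2c(Nc3ccc(OC(F)(F)F)cc3)ncnc21` gives in this assay only a limit, > 10000 nM, and that this value is a limit is recorded as the limit of > 10000 nM in this assay, at which 1 of the 2 values shown sits. For the measured compounds named here, compound 2 `CC(C)(C)n1ncc2c(Nc3ccc(OC(F)(F)F)cc3)ncnc21` gives in this assay 7300 nM, the only true number among the two values shown. Going by the values given here, the single measured step, an at least 1.3-fold lower number from compound 1 to compound 2 (0.13 log units; that floor lies within the scatter), therefore describes a change whose floor lies within the usual scatter.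

Compound 3 `NC(=O)Cn1ncc2c(Nc3ccc(OC(F)(F)F)cc3)ncnc21` differs from compound 2 by carbamoylmethyl in place of tert-butyl on an aromatic nitrogen. Among the compounds with values here, no measured step speaks directly to carbamoylmethyl in place of tert-butyl; the only step available, ethyl to tert-butyl, showed nothing beyond the scatter in this assay. With so little to go on, one expects no step beyond the scatter, with a fair chance that only a limit is returned again. Compound 3 is expected to give 9000 nM, within a range of 4000 nM to 20000 nM. The expected step is a 1.2-fold higher number from compound 2 to compound 3 (0.09 log units; within the scatter).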

Compound 3, half-maximal effective concentration: 3300 nM
Compound 3: middle estimate off by 2.7-fold (0.44 log units), on the high side; measured number outside the range, below it.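

In this assay, carbamoylmethyl in place of tert-butyl on the aromatic nitrogen gives a 2.2-fold lower number from compound 2 to compound 3 (0.34 log units; beyond the scatter), so a change at this position can move the read-out beyond the scatter, which the step from ethyl to tert-butyl could not show. Carbamoyl in place of methyl on the saturated chain carbon bound to the aromatic nitrogen gives an at least 3.0-fold lower number from compound 1 to compound 3 (0.48 log units; beyond the scatter), which leaves compound 3, the only one of the three with a hydrogen-bond donor and acceptor in this substituent, with the lowest number of the series. That second step is only a floor because compound 1 carries a limit rather than a number: the limit of > 10000 nM in this assay, at which 1 of the 3 values shown sits.

From the compounds shown here alone, how a carboxylic acid, an amine or a longer chain ending in the amide would read on this nitrogen stays open, and so does whether the carbonyl, the amide hydrogen or the chain goes with the lower number. The compounds shown also leave open whether a step of this size would hold with a group other than trifluoromethoxy on the shared core.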